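Hydrazone aryl variation on the shared core

The compounds below may be only part of what the source reports. "The series", "measured", "known", "first", "only" and "open" are said of these compounds alone.

Compound 1 `O=C(CSc1nnc(-c2ccncc2)o1)N/N=C/c1ccccc1` carries a phenyl on the hydrazone carbon; in a functional assay on BGC-823 cells (Homo sapiens) for cytotoxicity, read by MTT assay, with a stated time of 48 h (on this read-out higher numbers stand for weaker inhibition and lower numbers for stronger inhibition), compound 1 gives 22100 nM, the second highest of the three numbers, with compound 2 `Cc1ccc(/C=N/NC(=O)CSc2nnc(-c3ccncc3)o2)cc1` nearest at 21800 nM and compound 3 `O=C(CSc1nnc(-c2ccncc2)o1)N/N=C/c1ccco1` furthest at 25800 nM. Both steps away from compound 1 stay within the scatter: a 1.0-fold lower number from compound 1 to compound 2 (0.01 log units; within the scatter) and a 1.2-fold higher number from compound 1 to compound 3 (0.07 log units; within the scatter). Compound 4 `O=C(CSc1nnc(-c2ccncc2)o1)N/N=C/c1cccs1` is not yet measured; it differs from compound 1 by thiophen-2-yl in place of phenyl on a carbon with a double bond to nitrogen. The step to compound 3, where a five-membered aromatic ring likewise replaced the phenyl, bears most directly on this change and was flat, so no step beyond the scatter is expected in this assay. Compound 4 is therefore estimated at 23000 nM, within 12000 nM to 46000 nM, an expected 1.0-fold higher number from compound 1 to compound 4 (0.02 log units; within the scatter).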

Compound 4, half-maximal inhibitory concentration: 26700 nM
Compound 4: middle estimate off by 1.2-fold (0.06 log units), on the low side, and the stated range covers the measured number.
By their numbers in this assay, from the lowest: compounds 2, 1, 3 and 4 (each within the scatter of the next).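

Thiophen-2-yl on the carbon with a double bond to nitrogen extends the flat picture in this assay to a sulfur-bearing five-membered ring, with no step beyond the scatter against phenyl (a 1.2-fold higher number from compound 1 to compound 4 (0.08 log units; within the scatter)). The same holds against furan-2-yl (a 1.0-fold higher number from compound 3 to compound 4 (0.01 log units; within the scatter)) and against 4-methylphenyl (a 1.2-fold higher number from compound 2 to compound 4 (0.09 log units; within the scatter)). No measured evidence on these numbers is available.

Across these four compounds, this position has not yet given a step beyond the scatter. Open, on these data alone, is whether an amine or a carboxylic acid on the aromatic ring, or a longer chain in its place, would give one.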